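This account rests on a few compounds, and the source may have more. Where it says the series, first, only, none or still open, it means among the compounds named here.

Compounds built on one shared core have been tested in a functional assay on HepG2 cells (Homo sapiens) for cytotoxicity, read by MTT assay; on this read-out higher numbers stand for weaker inhibition and lower numbers for stronger inhibition. Compound 1 `COc1ccc(/C=C/C(=O)c2ccc(OC)c3c2OC(C)(C)C=C3)cc1OCCO`, which carries a 2-hydroxyethyl on an oxygen on an aromatic ring, reads > 10000 nM, and this is a limit of the assay. Compound 2 `COc1ccc(/C=C/C(=O)Oc2cc(/C=C/C(=O)c3ccc(OC)c4c3OC(C)(C)C=C4)ccc2OC)cc1` gives 430 nM, and compound 3 `COc1ccc(/C=C/C(=O)c2ccc(OC)c3c2OC(C)(C)C=C3)cc1OC(=O)c1ccco1` gives 370 nM. Within the data shown here, these two are the only exact numbers so far, and they stand level: a 1.2-fold lower number from compound 2 to compound 3 (0.07 log units; within the scatter). Swapping the 2-hydroxyethyl for either carbonyl group made a large difference: an at least 23-fold lower number from compound 1 to compound 2 (1.36 log units; beyond the scatter), and an at least 27-fold lower number from compound 1 to compound 3 (1.43 log units; beyond the scatter).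

Compound 4 `COc1ccc(/C=C/C(=O)c2ccc(OC)c3c2OC(C)(C)C=C3)cc1OS(=O)(=O)Cc1ccccc1` has not yet been measured. It has benzylsulfonyl in place of (furan-2-yl)carbonyl on an oxygen on an aromatic ring. Among the measured compounds shown here, no measured step tests a sulfonyl group here, so the guide is indirect. Two quite different carbonyl groups gave matching results in compound 2 and compound 3, which points to a small change, yet an at least 27-fold lower number from compound 1 to compound 3 (1.43 log units; beyond the scatter) warns that this oxygen's substituent can matter greatly. The expected result is a 1.6-fold higher number from compound 3 to compound 4 (0.21 log units; within the scatter), with the greater risk towards higher numbers. For compound 4 the estimated value is 600 nM, with an expected range of 180 nM to 3500 nM.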

Compound 4, half-maximal inhibitory concentration: > 10000 nM
Compound 4: a limit, no number (the forecaster's own chance of this, stated with the estimate: 15%); middle value at least 16-fold (1.22 log units) away from the limit.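

Two quite different carbonyl groups on this oxygen stood level, so the position seemed open to varied groups, but a sulfonyl link changes that in this assay: an at least 27-fold higher number from compound 3 to compound 4 (1.43 log units; beyond the scatter), and an at least 23-fold higher number from compound 2 to compound 4 (1.36 log units; beyond the scatter). Compound 4 reads > 10000 nM, which is a limit of the assay and not a number. Among the compounds shown, low numbers come only with a carbonyl group on this oxygen, and the step from compound 1 to compound 4 cannot be read because both sit at the limit: the limit of > 10000 nM in this assay, at which 2 of the 4 values shown sit.

Going by these compounds, what remains open is whether the sulfonyl or the benzyl part accounts for the loss, as compound 4 changes both at once. A phenylacetyl group on this oxygen would hold the benzyl part on a carbonyl, and a methylsulfonyl group would keep the sulfonyl without the benzyl.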